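The source may hold more compounds than are shown below. What is called first, only, known or untested is meant among the compounds shown, and "the series" means these compounds.

Compound 1 (`Cc1ccc(NC(=O)c2cccc(C(F)(F)F)c2)cc1N1Cc2cnc(NC3CCCCC3)nc2N(C)C1=O`): 5220 nM
Compound 2 (`Cc1ccc(Nc2ncc3c(n2)N(C)C(=O)N(c2cc(NC(=O)c4ccccc4)ccc2C)C3)cn1`): 2700 nM
Compound 3 (`CC(=O)N1CCN(c2ccc(Nc3ncc4c(n3)N(C)C(=O)N(c3cc(NC(=O)c5ccc(CN6CCC(N(C)C)C6)c(C(F)(F)F)c5)ccc3C)C4)cn2)CC1`): 187 nM

In an ADME assay on BaF3 cells (Mus musculus) for inhibition, read by CellTiter-Glo, with a stated time of 72 h (on this read-out lower numbers stand for stronger inhibition of growth and higher numbers for weaker inhibition of growth), compound 1 and compound 2 lie within the scatter of each other at the upper end of the numbers, while compound 3 lies beyond the scatter below compound 1. Compound 4 (`Cc1cc(Nc2ncc3c(n2)N(C)C(=O)N(c2cc(NC(=O)c4cccc(C(F)(F)F)c4)ccc2C)C3)n(C)n1`) is the next to be considered, and it differs from compound 1 as follows: 1,3-dimethyl-1H-pyrazol-5-yl in place of cyclohexyl on a nitrogen on an aromatic ring. Within the data shown here, no measured pair isolates this change. Compound 2 carries a different group on that nitrogen and also differs elsewhere, so its 2700 nM is only a loose guide. The expected step is small and downward, close to the scatter: a 1.7-fold lower number from compound 1 to compound 4 (0.24 log units; within the scatter). Compound 4 is estimated at 3000 nM (expected range 800 nM to 10000 nM).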

Compound 4, concentration for 50% growth inhibition: 2060 nM
The estimate for compound 4 lay 1.5-fold (0.16 log units) above the measured number, within the range that was stated.
By their numbers in this assay, from the lowest: compound 3; then compounds 4, 2 and 1 (each within the scatter of the next, the first and the last beyond it).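

Among these compounds, on a nitrogen on an aromatic ring, compound 4 gives the first comparison that changes only this group: in this assay, replacing cyclohexyl with 1,3-dimethyl-1H-pyrazol-5-yl brings a 2.5-fold lower number from compound 1 to compound 4 (0.40 log units; beyond the scatter) and a modest gain in growth inhibition. An aromatic five-membered ring with two hetero atoms is therefore tolerated here in place of the carbon-only ring. Nothing available explains this step. Still open, going by these compounds, is how a phenyl ring or an unsubstituted pyrazole would compare on that nitrogen, and whether the two methyl groups contribute to the step.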